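Replacing Methyl with Pyridin-2-yl on a Ring Nitrogen

The source may hold more compounds than are shown below. What is called first, only, known or untested is meant among the compounds shown, and "the series" means these compounds.

Measured compounds:
- compound 1, `COc1ccccc1N1CCN(CCCCCC(=O)c2ccccc2O)CC1`: 5.8 nM
- compound 2, `COc1ccccc1N1CCN(CCCCCC(=O)c2ccc(O)cc2)CC1`: 23.7 nM
- compound 3, `CN1CCN(CCCCCC(=O)c2ccccc2O)CC1`: > 1000 nM

Of the compounds shown here, three have been tested in an assay on isolated protein for binding affinity to 5-hydroxytryptamine receptor 7 (Rattus norvegicus); a higher number here means a weaker inhibitor, a lower number a stronger inhibitor. Compound 1 gives 5.8 nM and compound 2 gives 23.7 nM, the step of a 4.1-fold higher number from compound 1 to compound 2 (0.61 log units; beyond the scatter) being modest. For compound 3 only a limit is reported, > 1000 nM, so compound 3 stands at the limit of > 1000 nM in this assay, at which 1 of the 3 values shown sits, rather than at a measured number. The step of an at least 170-fold higher number from compound 1 to compound 3 (2.23 log units; beyond the scatter) is the largest difference in the set.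

Compound 4, `O=C(CCCCCN1CCN(c2ccccn2)CC1)c1ccccc1O`, differs from compound 3 in one place: pyridin-2-yl in place of methyl on an amine nitrogen in a ring. The step that bears on this change is an at least 170-fold higher number from compound 1 to compound 3 (2.23 log units; beyond the scatter), where an aromatic ring was exchanged for methyl and the number rose sharply. Compound 4 restores an aromatic ring at that position, although pyridin-2-yl is not the same group as 2-methoxyphenyl, so the full return to the level of compound 1 is uncertain. A large step downward beyond the scatter is therefore expected for compound 4, an at least 33-fold lower number from compound 3 to compound 4 (1.52 log units; beyond the scatter), and its estimated value in this assay is 30 nM, with a range from 5 nM to 200 nM.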

Compound 4, inhibition constant: 105 nM
For compound 4 the middle estimate is 3.5-fold (0.54 log units) below the measured one; the range from low to high includes it.
By their numbers in this assay, from the lowest: compound 1; then compound 2; then compound 4. At a limit, above all of these: compound 3.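

In this assay, pyridin-2-yl on the ring amine nitrogen gives a clear gain over methyl, an at least 9.5-fold lower number from compound 3 to compound 4 (0.97 log units; beyond the scatter), so the gain from an aromatic ring at this nitrogen is not confined to 2-methoxyphenyl. Compound 3 is reported only as a limit, so the true size of that step cannot be read and only its lower bound is known: the limit of > 1000 nM in this assay, at which 1 of the 4 values shown sits. An aromatic ring at this nitrogen does not by itself restore the full level, however, as the exchange of 2-methoxyphenyl for pyridin-2-yl on the same core shows, an 18-fold higher number from compound 1 to compound 4 (1.26 log units; beyond the scatter), and the identity of the aromatic group therefore matters here.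

What the compounds shown leave open is which part of that exchange accounts for the gap, the ring nitrogen of pyridin-2-yl or the loss of the methoxy group, and a plain phenyl group on this nitrogen would separate the two. Also open, on these data alone, is whether other groups on the pyridine ring, such as a methoxy group or a chlorine atom, would bring the number back towards that of compound 1.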